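A few compounds are considered here, and "the series" means these few. Any claim that something is new, unique, unknown or untested is made for them only; others in the source may bear on it.

Measured compounds:
- compound 1 `ClCc1ccc(Cn2cnc3c(Cl)ncnc32)cc1`: 6760 nM
- compound 2 `ClCc1cccc(Cn2cnc3c(Cl)ncnc32)c1`: 5120 nM

Both were run in a functional assay on HOP-62 cells (Homo sapiens) for cytotoxicity, read by sulforhodamine B assay, with a stated time of 48 h; on this read-out lower numbers stand for stronger inhibition of growth and higher numbers for weaker inhibition of growth. In this assay compound 1 gives 6760 nM and compound 2 gives 5120 nM. Compound 2 holds the lowest of the two numbers shown, but the nearest number, that of compound 1, lies within the scatter of the read-out, so no order between the two can be drawn from these values.

Compound 3 `ClCc1cccc(Cn2cnc3c(Cl)nc(Cl)nc32)c1` is compound 2 with one change: chloro in place of hydrogen on an aromatic carbon. The second chloro enters on the core of compound 2, on an aromatic carbon of a six-membered aromatic ring with two nitrogen, between two ring nitrogen atoms, meta to the chloro group already present.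

Among the compounds with values here, no pair of measured compounds shows a change of this kind, so there is no measured step to lean on. The change is small in size, and the expectation is for a step in this assay of modest size, more likely towards a lower number than a higher one, but not clearly beyond the scatter. For compound 3 the expected value is 4000 nM, with a range from 1500 nM to 10000 nM, which corresponds to an estimated step of a 1.3-fold lower number from compound 2 to compound 3 (0.11 log units; within the scatter).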

Compound 3, concentration for total growth inhibition: 4360 nM
For compound 3 the middle estimate is 1.1-fold (0.04 log units) below the measured one; measured number inside the range.
By their numbers in this assay, from the lowest: compounds 3, 2 and 1 (each within the scatter of the next).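

In this assay, chloro in place of hydrogen on an aromatic carbon, at the place between two ring nitrogen atoms, gives a 1.2-fold lower number from compound 2 to compound 3 (0.07 log units; within the scatter). Within the data shown here, this is the first step that changes one place on the shared core, and it shows that this position accepts a single chlorine atom with no readable change in growth inhibition, since the step stays inside the scatter. No supporting measurement bears on this result, so the data offer no account of it.

From the compounds shown here alone, one substituent at one position says little about how much room this carbon offers for change, so it remains open whether an amine, a methoxy group or a longer chain placed here would carry the number beyond the scatter in either direction. Going by these compounds, it also remains open whether the same chloro would give a comparable step on compound 1, where the second ring carries its substituent at a different place, and whether any result at this position would hold on other cell lines.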